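Amide nitrogen substituent series, step to compound 4

The source may report more compounds than this note shows. Statements on the series, on what has been measured and on what is new or still open speak of the compounds shown alone.

Measured so far in an assay on HEK293 cells for agonist activity at transient receptor potential cation channel subfamily M member 8 (Homo sapiens), read by fluorescence and calcium flux, with a stated time of 15 min; on this read-out lower numbers stand for an effect already at smaller amounts and higher numbers for an effect only at larger amounts of compound:
compound 1 `Cc1ccc(OCC(=O)N(Cc2cccs2)c2ccnn2C)cc1` gives 422 nM
compound 2 `Cc1ccc(OCC(=O)N(C)Cc2cccs2)cc1` gives 400 nM
compound 3 `Cc1ccc(OCC(=O)N(Cc2cccs2)c2ccn(C)n2)cc1` gives 855 nM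

Compound 3 stands highest of the three numbers; its nearest neighbour is compound 1 and its furthest compound 2, both beyond the scatter. Compound 4 `COCCN(Cc1cccs1)C(=O)COc1ccc(C)cc1` differs from compound 3 by 2-methoxyethyl in place of 1-methyl-1H-pyrazol-3-yl on an amide-type nitrogen.

Among the measured compounds shown here, two steps bear on this change: a 2.1-fold higher number from compound 2 to compound 3 (0.33 log units; beyond the scatter) and a 2.0-fold higher number from compound 1 to compound 3 (0.31 log units; beyond the scatter); both show the 1-methyl-1H-pyrazol-3-yl raising the number. Compound 2 and compound 1 themselves lie within the scatter, a 1.1-fold lower number from compound 1 to compound 2 (0.02 log units; within the scatter). Taking the 1-methyl-1H-pyrazol-3-yl away again is therefore expected to return the number modestly toward those two, an expected 1.9-fold lower number from compound 3 to compound 4 (0.28 log units; within the scatter) in this assay. Compound 4 is estimated at 450 nM, with a range of 200 nM to 1000 nM.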

Compound 4, half-maximal effective concentration: 400 nM
Estimate against measurement, compound 4: 1.1-fold (0.05 log units) above; low and high end bracket the measured number.
By their numbers in this assay, from the lowest: compounds 2, 4 and 1 (each within the scatter of the next); then compound 3.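

In this assay, a 2-methoxyethyl chain with no ring on the amide-type nitrogen stays level with both methyl and 1-methyl-1H-pyrazol-5-yl: no change at the digits printed from compound 2 to compound 4 (within the scatter) and a 1.1-fold lower number from compound 1 to compound 4 (0.02 log units; within the scatter). Of the groups shown at this position, only the 1-methyl-1H-pyrazol-3-yl of compound 3 stands apart, a 2.1-fold lower number from compound 3 to compound 4 (0.33 log units; beyond the scatter), so a ring is not required to reach this level. Nothing available explains why that one group stands apart.

Open, from the compounds shown here alone, is whether an amine, a carboxylic acid or a longer chain on this nitrogen would stay at the same level or move away from it.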